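The source may report more compounds than this note shows. Statements on the series, on what has been measured and on what is new or still open speak of the compounds shown alone.

Series notes. Compound 1 `COc1cc2c(/C=C3/C(=O)N(C)c4ccccc43)c(Cl)n(C)c2cc1C` and compound 2 `COc1cc2c(/C=C3/C(=O)N(C)c4ccc(O)cc43)c(Cl)n(C)c2cc1C` share one core; compound 3 `COc1cc2c(/C=C3/C(=O)N(C)c4ccccc43)c[nH]c2cc1C` and compound 4 `COc1cc2c(/C=C3/C(=O)N(C)c4ccc(O)cc43)c[nH]c2cc1C` share another. How the core of compound 1 differs from the core of compound 3 is not broken down here. In a functional assay on cells (Cancer cell lines, Homo sapiens) for inhibition, with a stated time of 48 h (on this read-out lower numbers stand for stronger inhibition of growth and higher numbers for weaker inhibition of growth), compound 1 gives 200 nM, compound 2 gives 40 nM and compound 3 gives 1070 nM. Compound 3 thus stands highest of the three measured, with compound 1 nearest and compound 2 furthest.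

The change from compound 1 to compound 2 is hydroxy in place of hydrogen on an aromatic carbon and brings a 5.0-fold lower number from compound 1 to compound 2 (0.70 log units; beyond the scatter). The change from compound 3 to compound 4 is hydroxy in place of hydrogen on an aromatic carbon, the same change at the same place, now carried out on the core of compound 3. Compound 4 is not yet measured in this assay.

The change has a single measured precedent, so the expected step is kept slightly short of it rather than carried over in full. Compound 4 is expected to show a 4.1-fold lower number from compound 3 to compound 4 (0.61 log units; beyond the scatter). On that basis compound 4 is estimated at 260 nM in this assay, with an expected range from 100 nM to 650 nM.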

Compound 4, concentration for 50% growth inhibition: 3720 nM
Beside the measured number, compound 4's estimate is 14-fold (1.16 log units) below it; measured number above the stated range.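

Measured on the other core, hydroxy in place of hydrogen on an aromatic carbon brings a 3.5-fold higher number from compound 3 to compound 4 (0.54 log units; beyond the scatter) in this assay, so the step does not keep its direction. Set against the earlier step, the change does not carry over from one core to the other in this series: the same change on two cores in this assay, a 5.0-fold lower number (0.70 log units; beyond the scatter) from compound 1 to compound 2 and a 3.5-fold higher number (0.54 log units; beyond the scatter) from compound 3 to compound 4, 17-fold (1.24 log units) apart, beyond the scatter of two such steps. This shows that, for these two pairs, the outcome of the change depends on the core that carries it, but it does not show which difference between the two cores is responsible, and two pairs give no rule for any further core.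

The compounds shown hold only hydrogen or hydroxy at this place on the ring, so it remains open whether a methoxy group, an amine or a carboxylic acid there would follow the step on either core. Also open, going by these compounds, is how the hydroxy step would behave on a core that carries only part of the difference between the two cores.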